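A few compounds are considered here, and "the series" means these few. Any claim that something is new, unique, unknown or untested is made for them only; others in the source may bear on it.

Of the compounds shown here, two sharing one core have been read so far in a functional assay on K562 cells (Homo sapiens) for antiproliferative activity, read by trypan blue exclusion, with a stated time of 48 h, tested at 10 uM; on this read-out higher numbers stand for more inhibition of growth at the one concentration tested and lower numbers for less inhibition of growth. Compound 1 `NC(=O)c1cc(Br)ccc1NC(=O)/C=C/c1ccccc1` gives 62.4%, and compound 2 `NC(=O)c1cc(Br)ccc1NC(=O)/C=C/c1ccccc1Br` gives 46.2%, the lower of the two numbers. Compound 3 `Cc1cccc(/C=C/C(=O)Nc2ccc(Br)cc2C(N)=O)c1` keeps the shared core and differs from compound 2 in one place: 3-methylphenyl in place of 2-bromophenyl on a double-bonded chain carbon bound to a double-bonded chain carbon. There, 3-methylphenyl stands in place of 2-bromophenyl on a double-bonded chain carbon bound to a double-bonded chain carbon. Going by the values given here, only one measured step bears on this change: a number 16.2 percentage points lower from compound 1 to compound 2 (beyond the scatter), with bromo in place of hydrogen on an aromatic carbon. Among the compounds with values here, compound 3 carries no bromo, and a move upward toward compound 1 at 62.4% is therefore expected, although no measured compound carries a methyl group. The expected change is modest and upward, a number 8.8 percentage points higher from compound 2 to compound 3 (within the scatter). In this assay, the estimate for compound 3 is 55%, with an expected range from 38% to 72%.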

Compound 3, percent growth inhibition at one concentration: 43.8%
Compound 3: the middle estimate sits 11.2 percentage points above what was measured; measured number inside the range.
By their numbers in this assay, from the lowest: compounds 3 and 2 (each within the scatter of the next); then compound 1.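

In this assay, the change from 2-bromophenyl to 3-methylphenyl on the double-bonded chain carbon shows little effect, with a number 2.4 percentage points lower from compound 2 to compound 3 (within the scatter). A methyl group on the phenyl ring gives a number 18.6 percentage points lower from compound 1 to compound 3 (beyond the scatter), so the separation from the unsubstituted phenyl of compound 1 seen with bromo in compound 2 also appears with a methyl group, and it does not depend on bromine alone among these three compounds. No measured evidence here explains either reading.

The two substituted rings differ in both the group and its place, so these compounds cannot separate the contribution of each. As far as these compounds go, it also remains open how this reading would respond to an amine or a carboxylic acid on the same ring.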